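Swapping a pentyl chain for a 2-methoxyethyl chain on a shared core

The source may report more compounds than this note shows. Statements on the series, on what has been measured and on what is new or still open speak of the compounds shown alone.

Of the compounds shown here, three built on the same core have been measured in a functional assay on MCF7 cells (Homo sapiens) for antiproliferative activity; a higher number here means a weaker inhibitor, a lower number a stronger inhibitor. Compound 1 `CCCCCn1c(Cc2cc(OC)c(OC)c(OC)c2)nc2c(N)nc(F)nc21` gives 36300 nM. Compound 2 `CC/C=C/Cn1c(Cc2cc(OC)c(OC)c(OC)c2)nc2c(N)ncnc21` gives 46800 nM, and compound 3 `CCCCCn1c(Cc2cc(OC)c(OC)c(OC)c2)nc2c(N)ncnc21` gives 61700 nM. All three numbers sit within the usual scatter of one another: the step of a 1.7-fold higher number from compound 1 to compound 3 (0.23 log units; within the scatter) and the step of a 1.3-fold higher number from compound 2 to compound 3 (0.12 log units; within the scatter) are both too small to call a real change, so compound 1 stands level with its two neighbours rather than apart from them.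

Compound 4 `COCCn1c(Cc2cc(OC)c(OC)c(OC)c2)nc2c(N)nc(F)nc21` has not yet been measured. It differs from compound 1 by methoxy in place of propyl on a saturated chain carbon, two bonds along the chain from an aromatic nitrogen. Within the data shown here, of the measured steps, only that from compound 2 to compound 3 touches the chain bound to the aromatic nitrogen, and it stayed within the scatter; no measured step exchanges chain carbons for an oxygen-bearing group, so nothing here points to a large shift in either direction in this assay. For compound 4 the estimate is therefore 40000 nM, within a range from 15000 nM to 110000 nM. The step this expects is a 1.1-fold higher number from compound 1 to compound 4 (0.04 log units; within the scatter), a change expected to stay within the scatter.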

Compound 4, half-maximal inhibitory concentration: 64600 nM
For compound 4 the middle estimate is 1.6-fold (0.21 log units) below the measured one; measured number inside the range.
By their numbers in this assay, from the lowest: compounds 1, 2, 3 and 4 (each within the scatter of the next).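

In this assay, exchanging a pentyl chain for a 2-methoxyethyl chain on the shared core gives a 1.8-fold higher number from compound 1 to compound 4 (0.25 log units; within the scatter) and so cannot be told apart from no change. The earlier chain step only compared two all-carbon chains, whereas this one brings an oxygen into the chain, and even this swap of atom type leaves the number inside the scatter. No supporting measurement is available to explain what the chain does at this position.

Going by these compounds, whether an amine or a carboxylic acid at the end of this chain, or a much longer chain, would move the number beyond the scatter remains open. Also open, on these data alone, is how the 2-methoxyethyl chain behaves on the core carrying hydrogen in place of fluoro.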